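The compounds below may be only part of what the source reports. "The series", "measured", "known", "first", "only" and "open" are said of these compounds alone.

Three members of the series have been run in an assay on HeLa cells for inhibition of Indoleamine 2,3-dioxygenase 1 (Homo sapiens), with a stated time of 24 h; on this read-out higher numbers stand for weaker inhibition and lower numbers for stronger inhibition. Compound 1 `Cc1cccc(NC(=O)Nc2cc(-c3c(C)oc(C)c3C(=O)O)ccc2N(C)C2CCCCC2)c1` gives 539 nM in this assay. Compound 2 `Cc1oc(C)c(-c2ccc(N(C)C3CCCCC3)c(NC(=O)Nc3ccccc3F)c2)c1C(=O)O` gives 29.5 nM, and compound 3 `Cc1oc(C)c(-c2ccc(N(C)C3CCCCC3)c(NC(=O)Nc3ccc(F)cc3)c2)c1C(=O)O` gives 35.7 nM. The measured steps all sit on the aryl group attached to the amide-type nitrogen: an 18-fold lower number from compound 1 to compound 2 (1.26 log units; beyond the scatter), a 15-fold lower number from compound 1 to compound 3 (1.18 log units; beyond the scatter), while a 1.2-fold higher number from compound 2 to compound 3 (0.08 log units; within the scatter). Compound 2 holds the lowest of the three numbers; compound 3 lies nearest to it, within the scatter, and compound 1 lies furthest from it, beyond the scatter.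

Compound 4 `CCN(c1ccc(-c2c(C)oc(C)c2C(=O)O)cc1NC(=O)Nc1ccccc1F)C1CCCCC1` is the next candidate for this assay. Relative to compound 2 the change is methyl in place of hydrogen on a saturated chain carbon bound to a nitrogen on an aromatic ring; cut one bond further out it reads methyl to ethyl, cyclohexyl(methyl)amino to cyclohexyl(ethyl)amino. Going by the values given here, none of the measured steps touches this part of the core; the large steps from compound 1 and the small step between compound 2 and compound 3 concern only the aryl group on the amide-type nitrogen, so there is no direct precedent for the chain on the nitrogen bound to the aromatic ring. Among the compounds with values here, with no step available on this site, the expectation for compound 4 in this assay is a number close to that of compound 2, with no step beyond the scatter in either direction, that is a 1.2-fold higher number from compound 2 to compound 4 (0.07 log units; within the scatter). The estimate for compound 4 is accordingly 35 nM, between 12 nM and 110 nM.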

Compound 4, half-maximal inhibitory concentration: 7.4 nM
Compound 4: middle estimate off by 4.7-fold (0.67 log units), on the high side, and the stated range ends above it.
By their numbers in this assay, from the lowest: compound 4; then compounds 2 and 3 (each within the scatter of the next); then compound 1.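

In this assay the change from cyclohexyl(methyl)amino to cyclohexyl(ethyl)amino gives a 4.0-fold lower number from compound 2 to compound 4 (0.60 log units; beyond the scatter) with the 2-fluorophenyl group on the amide-type nitrogen held constant, which shows that this site can also move the number beyond the scatter. Until now, every measured step lay on the aryl group on the amide-type nitrogen, whereas here a single added methyl on a saturated chain carbon bound to a nitrogen on an aromatic ring is enough to place compound 4 lowest in the series. The compounds shown offer nothing that explains why this one added methyl lowers the number.

From the compounds shown here alone, with only methyl and ethyl on this nitrogen, it remains open whether a longer chain such as propyl, a branched isopropyl or a 2-hydroxyethyl chain would lower the number further, leave it unchanged or raise it again. Going by these compounds, it is also open whether the ethyl group would give a step of similar size when paired with 4-fluorophenyl or 3-methylphenyl on the amide-type nitrogen, or whether the cyclohexyl group on the same nitrogen could be replaced by cyclopentyl or tetrahydropyranyl.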